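This account rests on a few compounds, and the source may have more. Where it says the series, first, only, none or still open, it means among the compounds named here.

Working notes on the series. Compound 1 `COc1ccc(-c2nc3cccc(-c4cc(OC)c(OC)c(OC)c4)c3o2)cc1OC` gives 2800 nM in a functional assay on A549 cells (Homo sapiens) for antiproliferative activity, read by MTT assay, with a stated time of 48 h; on this read-out higher numbers stand for weaker inhibition and lower numbers for stronger inhibition. For the measured compounds named here, compound 2 `COc1cc(-c2cccc3nc(-c4ccc(C)cc4)oc23)cc(OC)c1OC` gives 680 nM in this assay, and the step of a 4.1-fold lower number from compound 1 to compound 2 (0.61 log units; beyond the scatter) is the only measured step in the set. On the two numbers shown, compound 2 stands lowest; compound 1 is its nearest neighbour and sits beyond the scatter above it.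

Compound 3 `COc1cc(-c2cccc3nc(-c4cccs4)oc23)cc(OC)c1OC` differs from compound 2 by thiophen-2-yl in place of 4-methylphenyl on an aromatic carbon. Going by the values given here, the one measured step bears on it only loosely: it changed the group on the same aromatic carbon, from 3,4-dimethoxyphenyl to 4-methylphenyl, and was modest in size. Among the compounds with values here, no measured step shows a thiophen-2-yl at that place, so the direction of the change is not indicated by the data. The expectation is therefore a step of a 1.3-fold higher number from compound 2 to compound 3 (0.12 log units; within the scatter) that stays within the scatter, with a wide range on either side. Compound 3 is estimated at 900 nM in this assay, between 300 nM and 3000 nM.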

Compound 3, half-maximal inhibitory concentration: 12500 nM
For compound 3 the middle estimate is 14-fold (1.14 log units) below the measured one; the whole stated range lies below it.
By their numbers in this assay, from the lowest: compound 2; then compound 1; then compound 3.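

In this assay, the aromatic carbon next to the ring nitrogen and next to the ring oxygen proves far less tolerant than the earlier pair suggested: thiophen-2-yl in place of 4-methylphenyl gives an 18-fold higher number from compound 2 to compound 3 (1.26 log units; beyond the scatter). Thiophen-2-yl in place of 3,4-dimethoxyphenyl also moves the number up, with a 4.5-fold higher number from compound 1 to compound 3 (0.65 log units; beyond the scatter), so among these three compounds both groups with a six-membered aromatic ring of carbon only give lower numbers than the five-membered ring with sulfur. No evidence is available here to explain this difference.

The compounds shown leave open whether the rise follows the smaller ring, the sulfur atom or the loss of the methyl group. As far as these compounds go, how an unsubstituted phenyl, a furan-2-yl or a 4-aminophenyl would stand at this carbon also remains open.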